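Solubility notes on the shared core series

The compounds below may be only part of what the source reports. "The series", "measured", "known", "first", "only" and "open" are said of these compounds alone.

Measured so far:
- compound 1 `CNC(=O)c1cc(C(=O)NC2CC2)c(C)n(Cc2ccccc2)c1=O`; in a physicochemical assay for solubility, read by HPLC, in simulated intestinal fluid, with a stated time of 16 h, tested at 125 ug/mL (a lower number here means a less soluble compound, a higher number a more soluble compound), compound 1 gives 577 ug/mL
- compound 2 `CNC(=O)c1cc(C(=O)NC2CC2)cn(Cc2ccc3nc[nH]c3c2)c1=O`; in this assay compound 2 gives 225 ug/mL
- compound 3 `CNC(=O)c1cc(C(=O)NC2CC2)cn([C@H](C)c2ccccc2)c1=O`; in this assay compound 3 gives 815 ug/mL

Compound 2 holds the lowest of the three numbers. Its nearest neighbour is compound 1, whose number is higher by a gap beyond the scatter; compound 3 lies furthest from it, also beyond the scatter. No two of these compounds differ in only one place, so no single-point step can be drawn among them; the values are simply what they are.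

The next compound is compound 4 `CNC(=O)c1cc(C(=O)NC2CC2)cn(Cc2ccc(F)cc2)c1=O`. It differs from compound 2 in one place: 4-fluorophenyl in place of 1H-benzimidazol-6-yl on a saturated chain carbon bound to an aromatic nitrogen.

Compound 4 carries a substituent of the same kind as the ones in compound 1 and compound 3, both of which gave higher numbers than compound 2 in this assay. On that basis the step from compound 2 to compound 4 is expected to be upward and beyond the scatter, at about a 2.1-fold higher number from compound 2 to compound 4 (0.33 log units; beyond the scatter). For compound 4 the estimated solubility in this assay is 480 ug/mL, with an expected range from 220 ug/mL to 950 ug/mL.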

Compound 4, solubility: 84 ug/mL
Compound 4: middle estimate off by 5.7-fold (0.76 log units), on the high side; the whole stated range lies above it.
By their numbers in this assay, from the lowest: compound 4; then compound 2; then compounds 1 and 3 (each within the scatter of the next).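

In this assay the exchange of 1H-benzimidazol-6-yl for 4-fluorophenyl on a saturated chain carbon bound to an aromatic nitrogen gives a 2.7-fold lower number from compound 2 to compound 4 (0.43 log units; beyond the scatter) and so shows that this place is not indifferent to the aromatic group it carries. The entering group has 0 hydrogen-bond donors and 0 hydrogen-bond acceptors against 1 of each in the leaving group, a difference in count only, and the numbers alone do not tie the step to it. With 4-fluorobenzyl in place of 1-phenylethyl on an aromatic nitrogen, the series gives a 9.7-fold lower number from compound 3 to compound 4 (0.99 log units; beyond the scatter) and so shows that a single carbon-only aromatic ring in this substituent does not by itself bring a high number, and no measurement shown here gives a cause for either step.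

Open, as far as these compounds go, is how the step from 1-phenylethyl divides between the fluorine and the branching methyl, a split that plain benzyl on the aromatic nitrogen of the shared core would help to read. Open too, from the compounds shown here alone, is how this place responds to a basic amine such as morpholine or to a carboxylic acid on the aromatic ring.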